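Notes on the nitrogen substituent step to compound 4

A few compounds are considered here, and "the series" means these few. Any claim that something is new, unique, unknown or untested is made for them only; others in the source may bear on it.

Measured so far in an assay on isolated protein for inhibition of Discoidin domain-containing receptor 2 (Homo sapiens), read by ELISA, with a stated time of 60 min; on this read-out higher numbers stand for weaker inhibition and lower numbers for stronger inhibition:
compound 1 `Cc1ccc(C(=O)Nc2cccc(C(F)(F)F)c2)cc1-c1ccc2c(-c3cnn(C(C)C)c3)n[nH]c2c1` gives 7.7 nM
compound 2 `Cc1ccc(C(=O)Nc2cccc(C(F)(F)F)c2)cc1-c1ccc2c(-c3cnn(C4CC4)c3)n[nH]c2c1` gives 3.2 nM
compound 3 `Cc1ccc(C(=O)Nc2cccc(C(F)(F)F)c2)cc1-c1ccc2c(-c3cnn(CC(=O)N(C)C)c3)n[nH]c2c1` gives 2.7 nM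

Compound 3 has the lowest number of the three; its separation from compound 2 is within the scatter (a 1.2-fold lower number from compound 2 to compound 3 (0.07 log units; within the scatter)), while its separation from compound 1 lies beyond it (a 2.9-fold lower number from compound 1 to compound 3 (0.46 log units; beyond the scatter)). Compound 4 `Cc1ccc(C(=O)Nc2cccc(C(F)(F)F)c2)cc1-c1ccc2c(-c3cnn(C4CCOC4)c3)n[nH]c2c1` differs from compound 3 by oxolan-3-yl in place of (dimethylcarbamoyl)methyl on an aromatic nitrogen. All three measured steps change the substituent on this same aromatic nitrogen: a 2.4-fold lower number from compound 1 to compound 2 (0.38 log units; beyond the scatter) and a 2.9-fold lower number from compound 1 to compound 3 (0.46 log units; beyond the scatter) were modest, and a 1.2-fold lower number from compound 2 to compound 3 (0.07 log units; within the scatter) was within the scatter. The substituents tried there span a narrow range of numbers, so the expected step is a 1.5-fold higher number from compound 3 to compound 4 (0.17 log units; within the scatter), within the scatter. Compound 4 is estimated at 4 nM, with a range of 1.5 nM to 10 nM.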

Compound 4, half-maximal inhibitory concentration: 6.2 nM
The estimate for compound 4 lay 1.6-fold (0.19 log units) below the measured number; measured number inside the range.
By their numbers in this assay, from the lowest: compounds 3, 2, 4 and 1 (each within the scatter of the next, the first and the last beyond it).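

Among the four substituents on this aromatic nitrogen, oxolan-3-yl is the only non-aromatic ring with a hetero atom, and a 2.3-fold higher number from compound 3 to compound 4 (0.36 log units; beyond the scatter) shows that replacing (dimethylcarbamoyl)methyl with it is a modest step beyond the scatter. The other two comparisons do not separate it: a 1.9-fold higher number from compound 2 to compound 4 (0.29 log units; within the scatter) and a 1.2-fold lower number from compound 1 to compound 4 (0.09 log units; within the scatter) both stay within the scatter. Nothing available accounts for the step from compound 3 to compound 4.

Open, going by these compounds, is whether cyclopentyl, the all-carbon counterpart of oxolan-3-yl, would match compound 4. Also open, on these data alone, is whether an amine such as piperidin-4-yl or a carboxylic acid on a longer chain would stay within this narrow range.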